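Closing the Amide: Cyclopropylamino to Pyrrolidin-1-yl

The source may report more compounds than this note shows. Statements on the series, on what has been measured and on what is new or still open speak of the compounds shown alone.

Of the compounds shown here, three built on one shared core have been measured in a functional assay on PC-3 cells (Homo sapiens) for cytotoxicity, read by sulforhodamine B assay, with a stated time of 72 h; on this read-out higher numbers stand for weaker inhibition and lower numbers for stronger inhibition. Compound 1 `Nc1sc(-c2ccccc2)c(-c2ccc(Cl)cc2)c1C(=O)N1CCCC1` gives 22200 nM. For the measured compounds named here, compound 2 `Nc1sc(-c2ccc(Cl)cc2)c(-c2ccc(Cl)cc2)c1C(=O)N1CCCC1` gives 6220 nM, and the single one-point step among the measured set, a 3.6-fold lower number from compound 1 to compound 2 (0.55 log units; beyond the scatter), lies beyond the scatter. Compound 3 `Nc1sc(-c2ccc(Br)cc2)c(-c2ccc(Cl)cc2)c1C(=O)NC1CC1` gives 37300 nM, the highest number of the three; it sits within the scatter of compound 1 and clearly apart from compound 2.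

Compound 4 `Nc1sc(-c2ccc(Br)cc2)c(-c2ccc(Cl)cc2)c1C(=O)N1CCCC1` differs from compound 3 by pyrrolidin-1-yl in place of cyclopropylamino on a carbonyl carbon. Going by the values given here, no measured pair changes this amide group, so the step from compound 1 to compound 2 is the only measured guide, and it concerns a different position on the core. What remains is a comparison of the numbers: compound 3, with its cyclopropylamide, stands at the top, while compound 2 gives 6220 nM and carries the same pyrrolidin-1-yl amide that compound 4 bears, with only the bromo and chloro halides differing between them. On that basis a drop in the number is expected, a 5.3-fold lower number from compound 3 to compound 4 (0.73 log units; beyond the scatter), toward the region occupied by compound 2, though the absence of a direct amide comparison leaves the size uncertain. Compound 4 is estimated at 7000 nM, with a range from 2500 nM to 20000 nM.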

Compound 4, half-maximal inhibitory concentration: 37500 nM
Estimate against measurement, compound 4: 5.4-fold (0.73 log units) below; measured number outside the range, above it.
By their numbers in this assay, from the lowest: compound 2; then compounds 1, 3 and 4 (each within the scatter of the next).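

In this assay, this first measured change at the amide, pyrrolidin-1-yl in place of cyclopropylamino on a carbonyl carbon, shifts nothing beyond the scatter (a 1.0-fold higher number from compound 3 to compound 4 (0.00 log units; within the scatter)), and the amide hydrogen of compound 3 can go without a detectable difference in this pair. With pyrrolidin-1-yl held fixed, the aromatic substituent now separates the compounds: bromo in place of chloro on an aromatic carbon gives (a 6.0-fold higher number from compound 2 to compound 4 (0.78 log units; beyond the scatter)), while bromo in place of hydrogen stays within the scatter (a 1.7-fold higher number from compound 1 to compound 4 (0.23 log units; within the scatter)), so among these three pyrrolidin-1-yl amides the lower number belongs to the chloro compound 2 alone and does not extend to bromo. Nothing measured here accounts for this difference between chloro and bromo, or for the flat amide step. The compounds shown leave open whether the amide exchange would be equally silent with chloro in place of bromo, and whether piperidin-1-yl, morpholin-4-yl or dimethylamino on the same carbonyl carbon would behave like pyrrolidin-1-yl. They also leave open where fluoro, methyl or methoxy on the same aromatic carbon would fall relative to chloro and bromo.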